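Inverting One Ring Stereocentre in an Endoperoxide Acid

A few compounds are considered here, and "the series" means these few. Any claim that something is new, unique, unknown or untested is made for them only; others in the source may bear on it.

Going by the values given here, in a functional assay on T47D cells (Homo sapiens) for inhibition (on this read-out lower numbers stand for stronger inhibition of growth and higher numbers for weaker inhibition of growth), compound 2 `C=C1CCC[C@H]2[C@](C)(CC[C@]3(C)CC[C@H]([C@@H](C)C(=O)O)OO3)[C@@H](C)CC[C@]12C` gives 2000 nM, the only number among the three values shown. Compound 1 `CC(=O)CC/C=C(\C)CCC1=C(C)CCCC1(C)C` reaches only a limit, > 15000 nM. Compound 3 `C=C1CCCC(C)(C)C1CC[C@]1(C)CC[C@@H]([C@@H](C)C(=O)O)OO1` likewise stops at a limit, > 10000 nM. Compound 4 `C=C1CCC[C@H]2[C@](C)(CC[C@]3(C)CC[C@@H]([C@@H](C)C(=O)O)OO3)[C@@H](C)CC[C@]12C` has not yet been measured; it differs from compound 2 as follows: the two compounds have the same atoms and bonds and differ only in configuration as drawn: 1 of 7 stereo elements differ; a stereocentre at a saturated ring carbon is drawn R in compound 2 and S in compound 4. No step between two measured compounds is available, so the effect of this inversion cannot be read from the data shown; a modest step toward weaker inhibition, or none beyond the scatter, is expected for this change. Compound 4 is estimated at 4000 nM in this assay, within 1000 nM to 20000 nM. This estimate means an expected step of a 2.0-fold higher number from compound 2 to compound 4 (0.30 log units; within the scatter).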

Compound 4, concentration for 50% growth inhibition: 860 nM
For compound 4 the middle estimate is 4.7-fold (0.67 log units) above the measured one; measured number below the stated range.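

In this assay the inversion at this saturated ring carbon gives a 2.3-fold lower number from compound 2 to compound 4 (0.37 log units; beyond the scatter) and so forms the only readable step among the compounds shown. Going by these compounds alone, no two of the earlier compounds differ in one place, so they offered no such reading of this position. The step can be assigned to the configuration at this carbon alone because no atom or bond changes: the fact that compounds 2 and 4 differ only in the configuration as drawn.

From the compounds shown here alone, whether the same inversion gives a similar step when the carboxylic acid is replaced by a methyl ester or a primary amide stays open. Going by these compounds, the effect of inverting the other stereocentres also stays open.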